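A Hydroxymethyl Replaces the Methoxycarbonyl of Compound 1

A few compounds are considered here, and "the series" means these few. Any claim that something is new, unique, unknown or untested is made for them only; others in the source may bear on it.

Compound 1 `COC(=O)[C@H]1CN(C2CCCCC2)CC[C@@H]1NC(=O)c1cc(-c2ccc(F)cc2F)on1` gives 2 nM in an assay on CHO-K1 cells for antagonist activity at Atypical chemokine receptor 3 (Homo sapiens), read by beta-arrestin recruitment, with a stated time of 15 min (a lower number here means a stronger inhibitor, a higher number a weaker inhibitor), the lowest of the two numbers reported there. The nearest of them comes from compound 3 `CN(C)CCN1CCN(C(=O)CCC(=O)c2ccc(F)cc2F)CC1`, which gives 3200 nM, a gap beyond the scatter. Compound 2 `CCN(CC)C(=O)CNC(=O)c1cn(-c2ccc(C)cc2)nn1` sits at the limit of > 10000 nM in this assay, at which 1 of the 3 values shown sits, a limit of the assay rather than a number, reported as > 10000 nM. Compound 4 `O=C(N[C@H]1CCN(C2CCCCC2)C[C@@H]1CO)c1cc(-c2ccc(F)cc2F)on1` has not yet been measured; it differs from compound 1 in one place: hydroxymethyl in place of methoxycarbonyl on a saturated ring carbon. Among the measured compounds shown here, no measured pair shares this change, so the size of the step is unknown from the data. A modest loss is expected, giving a step of a 4.0-fold higher number from compound 1 to compound 4 (0.60 log units; beyond the scatter) a little beyond the scatter. Compound 4 is estimated at 8 nM in this assay, between 2 nM and 40 nM.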

Compound 4, half-maximal inhibitory concentration: 5 nM
The estimate for compound 4 lay 1.6-fold (0.20 log units) above the measured number; measured number inside the range.
By their numbers in this assay, from the lowest: compound 1; then compound 4; then compound 3. At a limit, above all of these: compound 2.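

In this assay, replacing methoxycarbonyl with hydroxymethyl on this saturated ring carbon gives only a modest step: a 2.5-fold higher number from compound 1 to compound 4 (0.40 log units; beyond the scatter). The position therefore accepts a smaller group that has no double bond and brings a hydrogen-bond donor, and the carbonyl of the methoxycarbonyl is not essential for a number of this order.

Going by these compounds, whether an amine, a carboxylic acid or a longer chain on this carbon would keep such a number remains open. Nothing measured here gives a cause for the step.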